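The compounds below may be only part of what the source reports. "The series", "measured", "known", "first", "only" and "open" are said of these compounds alone.

For the measured compounds named here, in a physicochemical assay for lipophilicity, measured as octanol-water partition (a lower number here means a more polar compound, a higher number a more lipophilic compound), compound 1 (`CC1=C(C(=O)OCc2cccnc2)C(c2cccc(O)c2)C2=C(CCCC2=O)N1`) gives 1.21 and is the lower of the two numbers so far. Compound 2 (`COc1ccc(C2C(C(=O)OCc3ccccn3)=C(C)NC3=C2C(=O)CCC3)cc1`) gives 1.9 and is the nearest value, with a gap beyond the scatter. Going by the values given here, these two compounds differ in more than one place, so the series offers no measured single-change step for sizing the next one.

Compound 3 (`CC1=C(C(=O)OCc2cccnc2)C(c2ccc([N+](=O)[O-])cc2)C2=C(CCCC2=O)N1`) is the core of compound 1 with one change, 4-nitrophenyl in place of 3-hydroxyphenyl on a saturated ring carbon. Among the compounds with values here, with no measured step as a guide, this estimate is tentative and the range is kept wide. A moderate upward step in this assay is expected, probably beyond the scatter, although the low end of the range would leave it within the scatter. Within the data shown here, the only other reference is compound 2 at 1.9 and it is a loose one, so compound 3 is expected to land near that region rather than clearly past it. The estimated step is a number 0.49 log units higher from compound 1 to compound 3 (beyond the scatter) on this reasoning. For compound 3 the expected value is 1.7 with an estimated range from 1.3 to 2.2 in this read-out.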

Compound 3, partition coefficient: 1.51
Beside the measured number, compound 3's estimate is 0.19 log units above it; the measured number falls inside the stated range.
By their numbers in this assay, from the lowest: compounds 1 and 3 (each within the scatter of the next); then compound 2.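

Working notes on the series: in this assay, the swap of 3-hydroxyphenyl for 4-nitrophenyl on the saturated ring carbon gives the first single-change step, a number 0.30 log units higher from compound 1 to compound 3 (within the scatter), and so the first direct reading at this position on the core of compound 1. The swap is not a small one on paper, with hydrogen-bond donors going from 1 to 0, hydrogen-bond acceptors from 1 to 2 and heavy atoms from 7 to 9, yet the printed step does not separate the two compounds in this read-out. No measured information on the origin of this result is available.

For the compounds shown here, this single step alters both the substituent and its place on the phenyl ring, so it cannot show what either alteration contributes alone, and compound 2 differs from compound 1 in more than one place and adds no second step. A 3-nitrophenyl or 4-hydroxyphenyl group on the same carbon would separate these two alterations, and a 4-aminophenyl group would show how a further group behaves at this position in this assay.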